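The source may report more compounds than this note shows. Statements on the series, on what has been measured and on what is new or still open speak of the compounds shown alone.

Among the compounds with values here, of the two numbers measured so far in a functional assay for agonist activity at G protein-coupled receptor 88 (Homo sapiens), read by HTRF and cAMP accumulation (on this read-out higher numbers stand for an effect only at larger amounts of compound and lower numbers for an effect already at smaller amounts), compound 2 `CC(C)C[C@H](N)CN(C(=O)[C@@H]1C[C@H]1c1ccccc1)c1ccc(C2=CCCC2)cc1` carries the higher one, giving 1200 nM, although this is not a real difference. Within the data shown here, the only other compound, compound 1 `CC(C)C[C@H](N)CN(C(=O)[C@@H]1C[C@H]1c1ccccc1)c1ccc(-c2ccccc2)cc1`, gives 880 nM. Among the measured compounds shown here, the single step available, a 1.4-fold higher number from compound 1 to compound 2 (0.13 log units; within the scatter), shows that swapping the group on this aromatic carbon changed little. Compound 3 `CC(C)C[C@H](N)CN(C(=O)[C@@H]1C[C@H]1c1ccccc1)c1ccc(C2=CCCCCC2)cc1` differs from compound 2 in one place: cyclohept-1-en-1-yl in place of cyclopent-1-en-1-yl on an aromatic carbon. Since that earlier step stayed within the scatter, a change of about the same small size or none is expected, a 1.3-fold higher number from compound 2 to compound 3 (0.10 log units; within the scatter). Compound 3 is therefore estimated at 1500 nM, with a range from 600 nM to 4000 nM.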

Compound 3, half-maximal effective concentration: 2100 nM
For compound 3 the middle estimate is 1.4-fold (0.15 log units) below the measured one; the range from low to high includes it.
By their numbers in this assay, from the lowest: compounds 1, 2 and 3 (each within the scatter of the next, the first and the last beyond it).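

With cyclohept-1-en-1-yl in place of cyclopent-1-en-1-yl, the result is a 1.8-fold higher number from compound 2 to compound 3 (0.24 log units; within the scatter), so this assay does not separate these two ring sizes at this position. Within the data shown here, replacing phenyl with the seven-membered ring gives the only step here that passes the scatter, though modestly: a 2.4-fold higher number from compound 1 to compound 3 (0.38 log units; beyond the scatter). Nothing measured explains this step.

On these data alone, whether a simple amine or a carboxylic acid at this position would give a lower number remains open. So does how cyclohex-1-en-1-yl would compare with these rings.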